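A few compounds are considered here, and "the series" means these few. Any claim that something is new, unique, unknown or untested is made for them only; others in the source may bear on it.

Measured so far in a functional assay on HepG2 cells (Homo sapiens) for antiproliferative activity, read by colorimetric assay and MTT assay, with a stated time of 48 h; a lower number here means a stronger inhibitor, a higher number a weaker inhibitor:
compound 1 `O=C(NS(=O)(=O)c1ccccc1)c1ccccn1` gives 9900 nM
compound 2 `O=C(NS(=O)(=O)c1ccc(Br)cc1)c1ccccn1` gives 5000 nM

Only these two numbers are available, and they lie within the scatter of each other, so compound 2 cannot be ranked against compound 1. Next comes compound 3 `Cc1ccc(S(=O)(=O)NC(=O)c2ccccn2)cc1`, with the change (methyl in place of bromo on an aromatic carbon), methyl in place of bromo, on an aromatic carbon of a six-membered aromatic ring of carbon only, para to a large group. Going by the values given here, no methyl analogue has been measured. Among the compounds with values here, the one step that bears on this change is at the same place: a 2.0-fold lower number from compound 1 to compound 2 (0.30 log units; within the scatter), with bromo in place of hydrogen. That step does not go beyond the scatter, so no clear shift is expected in this assay, in either direction. The estimated 1.4-fold higher number from compound 2 to compound 3 (0.15 log units; within the scatter) is not expected to exceed the scatter. For compound 3 the expected value is 7000 nM, with an estimated range from 3000 nM to 16000 nM.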

Compound 3, half-maximal inhibitory concentration: 12100 nM
Estimate against measurement, compound 3: 1.7-fold (0.24 log units) below; the range from low to high includes it.
By their numbers in this assay, from the lowest: compounds 2, 1 and 3 (each within the scatter of the next, the first and the last beyond it).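

At this position, on an aromatic carbon para to a large group, this assay now shows a first separation beyond the scatter: methyl in place of bromo gives a 2.4-fold higher number from compound 2 to compound 3 (0.38 log units; beyond the scatter) and so a modest gap between these two groups. Methyl in place of hydrogen gives a 1.2-fold higher number from compound 1 to compound 3 (0.09 log units; within the scatter) and stays within the scatter, so compound 1 and compound 3 cannot be ranked against each other, and bromo in compound 2 is separated only from methyl, not from hydrogen. No measured evidence is available to account for the gap between bromo and methyl.

On these data alone, whether other groups at this place, such as an amine, a carboxylic acid or a longer chain, would move beyond this narrow spread remains open. As far as these compounds go, the effect of changes elsewhere on the shared core is also open.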